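Swapping chloro for cyano on compound 3

This account rests on a few compounds, and the source may have more. Where it says the series, first, only, none or still open, it means among the compounds named here.

Values in an ADME assay on BJ cells (Homo sapiens) for cytotoxicity, with a stated time of 72 h; a higher number here means that more compound is needed for the effect, a lower number that less compound is needed:
Compound 1 `Cc1nn(-c2ccccc2)c2nc(-c3ccccc3)c(C#N)c(-c3ccccc3O)c12`: > 23000 nM, a limit
Compound 2 `Cc1nn(-c2ccccc2)c2nc(-c3ccc(C(C)C)cc3)c(C#N)c(-c3ccccc3O)c12`: 22600 nM
Compound 3 `Cc1nn(-c2ccccc2)c2nc(-c3ccc(Cl)cc3)c(C#N)c(-c3ccccc3O)c12`: > 20000 nM, a limit

Compound 3 has no exact number in this assay, only the limit > 20000 nM. Compound 4 `Cc1nn(-c2ccccc2)c2nc(-c3ccc(C#N)cc3)c(C#N)c(-c3ccccc3O)c12` carries cyano in place of chloro on an aromatic carbon. Going by the values given here, three measured steps bear on this change. Isopropyl in place of hydrogen gives an at least 1.0-fold lower number from compound 1 to compound 2 (0.00 log units; that floor lies within the scatter). Chloro in place of hydrogen gives a step that the two limits leave unreadable from compound 1 to compound 3. Chloro in place of isopropyl gives a step that the limit leaves unreadable from compound 2 to compound 3. Among the compounds with values here, none of these shows a change beyond the scatter, and compound 2 has the only exact value, 22600 nM. The expected step is a step that the limit leaves unreadable from compound 3 to compound 4, so no shift beyond the scatter is expected. For compound 4 the estimated value is 22000 nM, with an expected range from 11000 nM to 45000 nM.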

Compound 4, half-maximal effective concentration: > 20000 nM
Compound 4 was reported as a limit; the forecaster's own chance of this, stated with the estimate: 65%; the middle value lies beyond the limit too.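

In this assay compound 4 gives > 20000 nM, a limit. None of its steps from compound 1, compound 2 or compound 3 can be read. The compounds shown leave open whether cyano in place of chloro changes the number at all.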